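Replacing a pyridylmethyl amine with a benzyl propyl amine

The source may report more compounds than this note shows. Statements on the series, on what has been measured and on what is new or still open speak of the compounds shown alone.

Compound 1, with the structure `CCN(Cc1cccnc1)c1ccc(C(=O)N2CCc3ccc(OS(N)(=O)=O)cc3C2)cc1`, was measured in a physicochemical assay for lipophilicity (on this read-out lower numbers stand for lower lipophilicity and higher numbers for higher lipophilicity), and gave 1.93. Compound 2, with the structure `NS(=O)(=O)Oc1ccc2c(c1)CN(C(=O)c1ccc(N(CCCO)Cc3ccccc3)cc1)CC2`, gave 1.93 in this assay. Compound 1 therefore stands level with compound 2 at the digits shown, and the two values lie within the scatter of each other, so no order between them can be read.

The next compound, compound 3, has the structure `CCCN(Cc1ccccc1)c1ccc(C(=O)N2CCc3ccc(OS(N)(=O)=O)cc3C2)cc1`. It differs from compound 1 in one place: benzyl(propyl)amino in place of ethyl((pyridin-3-yl)methyl)amino on an aromatic carbon. For the measured compounds named here, no measured pair in this set shows this exact change on its own, so its size has to be expected rather than read from the data.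

For compound 3 an increase in this assay beyond the scatter is expected, since the group that enters has one more heavy atom and one fewer hydrogen-bond acceptor than the group that leaves, and the estimated step is a number 1.47 log units higher from compound 1 to compound 3 (beyond the scatter). Compound 3 is therefore expected to give about 3.4 in this assay, within a range from 2.7 to 4.1.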

Compound 3, partition coefficient: 1.93
The estimate for compound 3 lay 1.47 log units above the measured number; the whole stated range lies above it.
By their numbers in this assay, from the lowest: compounds 1, 2 and 3 (each within the scatter of the next).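

The exchange of ethyl((pyridin-3-yl)methyl)amino for benzyl(propyl)amino on an aromatic carbon, para to a large group, gives in this assay a step of no change at the digits printed from compound 1 to compound 3 (within the scatter), so at this position the six-membered aromatic ring of carbon only and the ring with a hetero atom cannot be told apart when the exchange comes together with the change of chain. For the compounds shown here, the second pair adds what the earlier compounds could not show, for hydrogen in place of hydroxy on a saturated chain carbon, three bonds along the chain from a nitrogen on an aromatic ring, gives a step of no change at the digits printed from compound 2 to compound 3 (within the scatter), and the end of the propyl chain thus carries either group with no order to be read between compound 2 and compound 3. Nothing available here explains why these compounds stand level.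

The compounds shown leave open how each part of the first exchange behaves alone, since the ethyl group and the pyridin-3-yl ring are replaced together. They also leave open whether the level values would hold with a carboxylic acid or a primary amine at the end of the chain, with a longer chain such as hexyl, or with a fluorine on the benzyl ring.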